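The source may hold more compounds than are shown below. What is called first, only, known or untested is meant among the compounds shown, and "the series" means these compounds.

Three close analogues built on one shared core have been tested in a functional assay on KB cells (Homo sapiens) for cytotoxicity, read by sulforhodamine B assay; a higher number here means a weaker inhibitor, a lower number a stronger inhibitor. Compound 1 `C=C1[C@@H](OC(C)=O)C[C@@H]2[C@](C)(COC=O)[C@H](OC(C)=O)CC[C@@]2(C)[C@@H]1C[C@@H](Nc1ccc(OC)cc1)C1=CCOC1=O` gives 32700 nM. Compound 2 `C=C1[C@@H](OC(C)=O)C[C@@H]2[C@](C)(COC=O)[C@H](OC(C)=O)CC[C@@]2(C)[C@@H]1C[C@@H](Nc1cccc(F)c1)C1=CCOC1=O` gives 28600 nM, and compound 3 `C=C1[C@@H](OC(C)=O)C[C@@H]2[C@](C)(COC=O)[C@H](OC(C)=O)CC[C@@]2(C)[C@@H]1C[C@@H](Nc1ccccc1F)C1=CCOC1=O` gives 29000 nM. The steps of a 1.1-fold lower number from compound 1 to compound 2 (0.06 log units; within the scatter) and a 1.1-fold lower number from compound 1 to compound 3 (0.05 log units; within the scatter) show that exchanging the aryl group on the amine nitrogen leaves the number essentially where it was, and a 1.0-fold higher number from compound 2 to compound 3 (0.01 log units; within the scatter) says the same for the exchange of 3-fluorophenyl for 2-fluorophenyl. Compound 3 therefore stands with the other two, its value within the scatter of both of theirs, and no order among the three can be read from these numbers.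

Compound 4 `C=C1[C@@H](OC(C)=O)C[C@@H]2[C@](C)(COC=O)[C@H](OC(C)=O)CC[C@@]2(C)[C@@H]1C[C@@H](Nc1ccc(F)cc1)C1=CCOC1=O` differs from compound 3 by 4-fluorophenyl in place of 2-fluorophenyl on an amine nitrogen. Because a 1.0-fold higher number from compound 2 to compound 3 (0.01 log units; within the scatter) for a fluorophenyl exchange on this nitrogen, and likewise a 1.1-fold lower number from compound 1 to compound 2 (0.06 log units; within the scatter) and a 1.1-fold lower number from compound 1 to compound 3 (0.05 log units; within the scatter) for the larger exchanges there, all lie within the scatter, the step to compound 4 is expected to be none beyond the scatter, namely a 1.0-fold higher number from compound 3 to compound 4 (0.01 log units; within the scatter). Compound 4 is thus expected to give about 29500 nM in this assay, with a range from 15000 nM to 60000 nM.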

Compound 4, half-maximal inhibitory concentration: 22900 nM
Compound 4: the middle estimate sits 1.3-fold (0.11 log units) above what was measured; low and high end bracket the measured number.
By their numbers in this assay, from the lowest: compounds 4, 2, 3 and 1 (each within the scatter of the next).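

With all three fluorophenyl groups now in hand, the place of the fluorine on the group on this amine nitrogen makes no readable difference in this assay: a 1.3-fold lower number from compound 3 to compound 4 (0.10 log units; within the scatter) and a 1.2-fold lower number from compound 2 to compound 4 (0.10 log units; within the scatter) both lie within the scatter. The direct exchange of fluoro for methoxy on an aromatic carbon, a 1.4-fold lower number from compound 1 to compound 4 (0.15 log units; within the scatter) also within the scatter, adds that the same position tolerates this change of substituent without a readable shift, so the four compounds cannot be ranked. No measurement is available that bears on this result.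

On these data alone, all four compounds carry a substituted phenyl group on this nitrogen, so it remains open whether a pyridyl group or a benzyl group there would move the number beyond the scatter. As far as these compounds go, it also remains open whether a carboxylic acid or a trifluoromethyl group on the phenyl would do so.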